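A few compounds are considered here, and "the series" means these few. Any claim that something is new, unique, unknown or untested is made for them only; others in the source may bear on it.

Values in a functional assay on MCF7 cells (Homo sapiens) for inhibition, read by CCK-8 assay, with a stated time of 72 h; a lower number here means a stronger inhibitor, a higher number a weaker inhibitor:
Compound 1 `O=C(/C=C/c1cccnc1)NCCCCCc1cccc(S(=O)(=O)Nc2ccccc2)c1`: 12.5 nM
Compound 2 `O=C(/C=C/c1cccnc1)NCCCCCCc1cccc(S(=O)(=O)Nc2ccccc2)c1`: 0.63 nM
Compound 3 `O=C(/C=C/c1cccnc1)NCCCCCCCc1cccc(S(=O)(=O)Nc2ccccc2)c1`: 42.6 nM

Compound 2 holds the lowest of the three numbers, and compound 1 and compound 3 both lie higher, beyond the scatter. Among the compounds with values here, these three differ only in chain length, so no measured pair shows what a change at the phenyl does.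

Compound 4 `Cc1ccc(C)c(NS(=O)(=O)c2cccc(CCCCCCNC(=O)/C=C/c3cccnc3)c2)c1` departs from compound 2 as follows: 2,5-dimethylphenyl in place of phenyl on a sulfonamide nitrogen. This places 2,5-dimethylphenyl in place of phenyl on a sulfonamide nitrogen.

Within the data shown here, with no direct precedent, a small rise in the number is expected in this assay, partly since compound 2 at 0.63 nM already sits lowest. The expected change is a 3.2-fold higher number from compound 2 to compound 4 (0.50 log units; beyond the scatter). For compound 4 the estimate is 2 nM, with an expected range of 0.4 nM to 12 nM.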

Compound 4, half-maximal inhibitory concentration: 0.6 nM
Beside the measured number, compound 4's estimate is 3.3-fold (0.52 log units) above it; measured number inside the range.
By their numbers in this assay, from the lowest: compounds 4 and 2 (each within the scatter of the next); then compound 1; then compound 3.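

In this assay, within the data shown here, the first measured change at the phenyl on the sulfonamide nitrogen gives no shift beyond the scatter: a 1.1-fold lower number from compound 2 to compound 4 (0.02 log units; within the scatter). This position therefore accepts 2,5-dimethylphenyl in place of phenyl with the chain of compound 2 unchanged. No available evidence bears on the reason for this result.

Still open, as far as these compounds go, is whether a single methyl, a chlorine, a methoxy group or a pyridine ring would be accepted here in the same way. Also open, from the compounds shown here alone, is how 2,5-dimethylphenyl would read on the chains of compound 1 and compound 3.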